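The source may hold more compounds than are shown below. What is called first, only, known or untested is meant among the compounds shown, and "the series" means these compounds.

Working notes on the series. In a functional assay on B16-F0 cells (Mus musculus) for inhibition, read by CCK-8 assay, with a stated time of 48 h (on this read-out lower numbers stand for stronger inhibition and higher numbers for weaker inhibition), compound 2 `COc1cc(-c2ccnc3cc(-c4ccc(Cl)cc4)nn23)cc(OC)c1OC` gives 4090 nM and compound 3 `Cn1ccc2cc(-c3cc4nccc(-c5ccc(F)cc5)n4n3)ccc21` gives 4780 nM. Among the compounds with values here, these are the only two numbers so far, and they lie within the usual scatter of each other, so no order can be drawn between them. Compound 1 `COc1cc(-c2cc3nccc(-c4c[nH]c5ccccc45)n3n2)cc(OC)c1OC` returns only a limit, > 10000 nM, and not a number.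

The next compound is compound 4 `COc1cc(-c2ccnc3cc(-c4ccc5cc[nH]c5c4)nn23)cc(OC)c1OC`, which follows from compound 2 by one change: 1H-indol-6-yl in place of 4-chlorophenyl on an aromatic carbon of the five-membered aromatic ring of the shared core (1H-indol-6-yl in place of 4-chlorophenyl on an aromatic carbon). Within the data shown here, the counted difference is the whole of what is known about this swap, since no measured pair isolates a single change. Any expectation for its size is therefore loose.

Starting from compound 2 at 4090 nM, a move toward stronger inhibition in this assay is expected, probably beyond the scatter, though an unchanged result would not be a surprise. The expected change is an 8.2-fold lower number from compound 2 to compound 4 (0.91 log units; beyond the scatter), and this size is an estimate only. For compound 4 the estimated value is 500 nM, with an expected range of 30 nM to 6000 nM.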

Compound 4, half-maximal inhibitory concentration: 55 nM
Estimate against measurement, compound 4: 9.1-fold (0.96 log units) above, within the range that was stated.
By their numbers in this assay, from the lowest: compound 4; then compounds 2 and 3 (each within the scatter of the next). At a limit, above all of these: compound 1.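

Within the data shown here, compound 4 gives the first readable step: a 74-fold lower number from compound 2 to compound 4 (1.87 log units; beyond the scatter) in this assay, a large shift that places the value well clear of the scatter. It shows that this position, an aromatic carbon of the five-membered aromatic ring with 2 nitrogen, is not indifferent to the group it carries, which compounds 1, 2 and 3 could not show, as no two of them differ in one place. The change is a composite one, however: 4-chlorophenyl leaves with its chlorine, while 1H-indol-6-yl brings a second aromatic ring and 1 hydrogen-bond donor, and the step reads these only together.

Nothing measured on either group bears on the reason for this step. The compounds shown leave open which part of the exchange carries the shift, and whether it holds for a plain phenyl, a 1-methyl-1H-indol-6-yl or a 1H-indol-5-yl group at this position, or for an amine or a carboxylic acid on the indole ring.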